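The compounds below may be only part of what the source reports. "The series", "measured", "known", "first", "only" and "open" are said of these compounds alone.

Of the compounds shown here, three have been measured so far, and all three end at the same limit. Compound 1 `Cc1cccc2nc(-c3cccc([N+](=O)[O-])c3)c(=O)n(Cc3ccccc3)c12` was tested in an assay on cells for activation of Cystic fibrosis transmembrane conductance regulator (Homo sapiens), read by fluorescence, with a stated time of 10 min (a lower number here means that less compound is needed, a higher number that more compound is needed for the effect), and compound 1 gives only a limit of the assay, > 10000 nM. Compound 2 `O=c1[nH]c2ccccc2nc1-c1cccc([N+](=O)[O-])c1` also reaches only a limit in this assay, namely > 10000 nM. Compound 3 `Cn1c(=O)c(-c2cccc([N+](=O)[O-])c2)nc2ccccc21` likewise shows only a limit in this assay, > 10000 nM. Going by the values given here, the single one-place step among them, a step that the two limits leave unreadable from compound 2 to compound 3, is unreadable, as both ends sit at the limit (the limit of > 10000 nM in this assay, at which 3 of the 3 values shown sit). On the numbers shown, compound 3 therefore stands at the limit, indistinguishable from the other two.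

Compound 4 `O=c1c(-c2cccc([N+](=O)[O-])c2)nc2ccccc2n1Cc1ccc2ccccc2c1` differs from compound 3 by naphthalen-2-yl in place of hydrogen on a saturated chain carbon bound to an aromatic nitrogen. Among the compounds with values here, no measured step bears directly on a change of this kind; the only step, a step that the two limits leave unreadable from compound 2 to compound 3, gives no size. A larger group than that of compound 3 is carried by compound 1, which nonetheless remained at the limit, > 10000 nM. Compound 4 is therefore expected to stay near the limit as well, estimated at 10000 nM with a range from 3000 nM to 30000 nM. The expected step of a number no higher from compound 3 to compound 4 (the limit leaves the size open) is thus none beyond the scatter.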

Compound 4, half-maximal effective concentration: 4300 nM
Beside the measured number, compound 4's estimate is 2.3-fold (0.37 log units) above it; the range from low to high includes it.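

In this assay, naphthalen-2-yl in place of hydrogen on a saturated chain carbon bound to an aromatic nitrogen gives an at least 2.3-fold lower number from compound 3 to compound 4 (0.36 log units; beyond the scatter), the first step among these compounds whose direction can be read. This shows that a change at this place can move the number, and that the shared core can carry a group this large and still give a measurable effect. Compound 4 is also the only compound here with a real number rather than a limit: the limit of > 10000 nM in this assay, at which 3 of the 4 values shown sit.

The compounds shown leave open whether the two aromatic rings of naphthalen-2-yl are what matters, or whether a group without them, such as a longer saturated carbon chain or a chain ending in an amine or a carboxylic acid, would serve as well at this place. A single step also cannot show how much further the number could fall with other groups here.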